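The compounds below may be only part of what the source reports. "The series", "measured", "known", "first", "only" and "open" are said of these compounds alone.

Compound 1 `Cc1ccc2[nH]c(-n3[nH]c(C)c(Cc4ccccc4)c3=O)nc2c1`: 670 nM
Compound 2 `Cc1ccc2[nH]c(-n3[nH]c(C)c(Cc4ccc(C(C)(C)C)cc4)c3=O)nc2c1`: 3700 nM

In an assay on isolated protein for inhibition of alpha-ketoglutarate-dependent dioxygenase alkB homolog 3 (Homo sapiens), read by polymerase chain reaction, with a stated time of 1 h (a lower number here means a stronger inhibitor, a higher number a weaker inhibitor), compound 1 gives 670 nM, the lower of the two numbers measured. Compound 2 gives 3700 nM, and the step of a 5.5-fold higher number from compound 1 to compound 2 (0.74 log units; beyond the scatter) lies beyond the scatter. Compound 3 `Cc1[nH]n(-c2nc3cc(-c4ccc(Cl)cc4)ccc3[nH]2)c(=O)c1Cc1ccccc1` has not been measured in this assay. It differs from compound 1 by 4-chlorophenyl in place of methyl on an aromatic carbon. Among the measured compounds shown here, the single measured step, a 5.5-fold higher number from compound 1 to compound 2 (0.74 log units; beyond the scatter), concerns a different place in the molecule, where a tert-butyl group entered, so it bears on the new change only loosely: the one enlargement seen so far gave a higher number. For the measured compounds named here, no step at the place where the 4-chlorophenyl enters is available, so the direction is open. The expected step of a 2.2-fold higher number from compound 1 to compound 3 (0.35 log units; beyond the scatter) is therefore judged modest, leaning toward a higher number, with wide uncertainty. Compound 3 is estimated at 1500 nM, within the range 300 nM to 8000 nM.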

Compound 3, half-maximal inhibitory concentration: 1500 nM
The estimate for compound 3 equals the measured number at the digits printed; the measured number falls inside the stated range.
By their numbers in this assay, from the lowest: compound 1; then compound 3; then compound 2.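

In this assay, among the compounds shown here, this is the first reading at the aromatic carbon that carries methyl in compound 1, and it shows that this place tolerates 4-chlorophenyl with only a modest change (a 2.2-fold higher number from compound 1 to compound 3 (0.35 log units; beyond the scatter)). The direction matches that of the one earlier enlargement, at a different place, where tert-butyl entered (a 5.5-fold higher number from compound 1 to compound 2 (0.74 log units; beyond the scatter)), so among the compounds shown, neither added group gives a lower number than compound 1. Nothing available here accounts for the size of the new step.

The compounds shown leave open whether the higher number goes with the added phenyl ring or with its chlorine, which a plain phenyl or a lone chlorine at this place would separate. As far as these compounds go, how an amine or a carboxylic acid on the new ring would read also remains open.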